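Swapping Butyl for Trifluoromethoxy on the Anilino Ring

This account rests on a few compounds, and the source may have more. Where it says the series, first, only, none or still open, it means among the compounds named here.

Of the compounds shown here, three sharing one core have been measured in an assay on mitochondria from L6 cells (Rattus norvegicus) for activation, with a stated time of 90 min; on this read-out higher numbers stand for an effect only at larger amounts of compound and lower numbers for an effect already at smaller amounts. Compound 1 `CCCCc1ccc(Nc2nc3nonc3nc2O)cc1` gives 2100 nM. Compound 2 `CCCCc1ccc(Nc2nc3nonc3nc2O)c(F)c1` gives 1100 nM, the lowest of the three numbers, yet a 1.9-fold lower number from compound 1 to compound 2 (0.28 log units; within the scatter), so compound 1 cannot be set apart from it. Compound 3 `Oc1nc2nonc2nc1Nc1cccc(C(F)(F)F)c1F` gives 4900 nM, and the gap between compound 3 and compound 2 lies beyond the scatter.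

The new compound 4 `Oc1nc2nonc2nc1Nc1ccc(OC(F)(F)F)cc1F` differs from compound 2 in a single place: trifluoromethoxy in place of butyl on an aromatic carbon. Among the compounds with values here, none of the measured steps bears directly on this change; the only step available exchanges hydrogen for fluoro, and none removes a butyl group or introduces a trifluoromethoxy group. With no guide among the measured pairs, the expected outcome in this assay for compound 4 is a number close to that of compound 2, with wide uncertainty in either direction, so that a 2.3-fold higher number from compound 2 to compound 4 (0.36 log units; beyond the scatter) is the estimated step. Compound 4 is therefore expected to give 2500 nM, estimated to fall between 800 nM and 8000 nM.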

Compound 4, half-maximal effective concentration: 2300 nM
Beside the measured number, compound 4's estimate is 1.1-fold (0.04 log units) above it, and the stated range covers the measured number.
By their numbers in this assay, from the lowest: compounds 2, 1 and 4 (each within the scatter of the next, the first and the last beyond it); then compound 3.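

Measured in this assay the exchange of butyl for trifluoromethoxy, on the aromatic carbon meta to a fluoro group and para to a large group, gives a 2.1-fold higher number from compound 2 to compound 4 (0.32 log units; beyond the scatter) and so counts as a modest step, though one beyond the scatter. Butyl is thus not required at this place for an effect to be read: until now, the only readable step had left that chain untouched, whereas here an all-carbon chain gives way to a group of carbon, oxygen and fluorine with only a modest shift. Nothing measured on these compounds accounts for the size or direction of this step.

Going by these compounds, whether the step follows from the oxygen or from the fluorines stays open, and a methoxy group or a difluoromethoxy group at this place would help to separate the two. On these data alone, how a longer chain such as hexyl or an amine would fare here, and whether the exchange gives a similar step on the core without the fluoro group, also remains unknown.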